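Working notes on substituent exchange at the ring amine nitrogen

A few compounds are considered here, and "the series" means these few. Any claim that something is new, unique, unknown or untested is made for them only; others in the source may bear on it.

Measured compounds:
compound 1, `CC(C)N1CCN(Cc2csc(N)c2C(=O)c2ccc(Cl)cc2)CC1`, 0%
compound 2, `Nc1scc(CN2CCN(c3ccc(Cl)c(C(F)(F)F)c3)CC2)c1C(=O)c1ccc(Cl)cc1`, 0%

In an assay on CHO cells for displacement of a labelled ligand from adenosine receptor A1 (Homo sapiens), read by scintillation counting, with a stated time of 120 min, tested at 10 uM (on this read-out lower numbers stand for less inhibition and higher numbers for more inhibition at the one concentration tested (going by the name of the read-out)), compound 1 gives 0%. In this assay compound 2 gives 0%. Compound 2 therefore stands level with compound 1: the step of no change at the digits printed from compound 1 to compound 2 (within the scatter) lies within the scatter.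

Compound 3, `Nc1scc(CN2CCN(c3ccc(OC(F)(F)F)cc3)CC2)c1C(=O)c1ccc(Cl)cc1`, differs from compound 2 by 4-(trifluoromethoxy)phenyl in place of 4-chloro-3-(trifluoromethyl)phenyl on an amine nitrogen in a ring. Among the measured compounds shown here, the only measured step bearing on this, no change at the digits printed from compound 1 to compound 2 (within the scatter), changed the same ring nitrogen substituent and produced nothing beyond the scatter. The expected step of no change at the digits printed from compound 2 to compound 3 (within the scatter) is accordingly none beyond the scatter. For compound 3 the estimate in this assay is 0%, expected within -5% to 12%.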

Compound 3, a percentage reported as inhibition, at one concentration (the size of the read-out at that concentration, not a potency): 0%
Compound 3: middle estimate and measured number agree at the digits printed; the measured number falls inside the stated range.
By their numbers in this assay, from the lowest: compounds 1, 2 and 3 (each within the scatter of the next).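

The exchange gives no change at the digits printed from compound 2 to compound 3 (within the scatter) in this assay even though the entering 4-(trifluoromethoxy)phenyl carries a hydrogen-bond acceptor and the leaving 4-chloro-3-(trifluoromethyl)phenyl carries none. Against isopropyl the same group gives no change at the digits printed from compound 1 to compound 3 (within the scatter) and so a second aryl group on this amine nitrogen in a ring reads like the first. No measurement at hand offers an explanation for this flat result.

As far as these compounds go, whether an amine or a carboxylic acid on a longer chain at this nitrogen would read differently remains open. So does whether any change elsewhere on the shared core would shift the read-out.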